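Swapping a Fluorophenyl Arm for Thiophene

The source may report more compounds than this note shows. Statements on the series, on what has been measured and on what is new or still open speak of the compounds shown alone.

Measured so far in a functional assay on trachea (Cavia porcellus) for activation; on this read-out higher numbers stand for weaker inhibition and lower numbers for stronger inhibition:
Compound 1, `COc1nc(-c2ccc3ccccc3c2)cc(-c2ccc(Cl)cc2Cl)c1C#N`, gives 9400 nM.
Compound 2, `COc1nc(-c2ccc(F)cc2)cc(-c2ccc(Cl)cc2Cl)c1C#N`, gives 7430 nM.
Compound 3, `CCOc1nc(-c2ccc(F)cc2)cc(-c2ccc(Cl)cc2Cl)c1C#N`, gives 8020 nM.

Compound 2 sits at the low end of these three, yet the step of a 1.1-fold higher number from compound 2 to compound 3 (0.03 log units; within the scatter) and the gap to compound 1 both lie within the scatter, so the three cannot be told apart. Compound 4, `COc1nc(-c2cccs2)cc(-c2ccc(Cl)cc2Cl)c1C#N`, carries thiophen-2-yl in place of 4-fluorophenyl on an aromatic carbon. Among the compounds with values here, no measured step touches this arm; the only step on record, from compound 2 to compound 3, concerns the alkoxy group and stays within the scatter. With nothing to point either way, compound 4 is expected to give 7500 nM, spanning 2500 nM to 25000 nM, an expected step of a 1.0-fold higher number from compound 2 to compound 4 (0.00 log units; within the scatter) with no change beyond the scatter.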

Compound 4, half-maximal inhibitory concentration: 3280 nM
The estimate for compound 4 lay 2.3-fold (0.36 log units) above the measured number; the measured number falls inside the stated range.
By their numbers in this assay, from the lowest: compound 4; then compounds 2, 3 and 1 (each within the scatter of the next).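

In this assay, within the data shown here, the arm next to the ring nitrogen is the first place where one change moves the number beyond the scatter: thiophen-2-yl in place of 4-fluorophenyl gives a 2.3-fold lower number from compound 2 to compound 4 (0.36 log units; beyond the scatter) and is a modest step. A five-membered aromatic ring with one sulfur is therefore accepted at this position without any loss. Nothing available explains the step. The compounds shown leave open whether a furan-2-yl or thiophen-3-yl arm would behave like thiophen-2-yl, and whether an ethoxy group would change anything alongside thiophen-2-yl.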